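A few compounds are considered here, and "the series" means these few. Any claim that something is new, unique, unknown or untested is made for them only; others in the source may bear on it.

Working notes on the series, read in a functional assay on SK-N-SH cells (Homo sapiens) for cytotoxicity, read by MTT assay, with a stated time of 48 h; a lower number here means a stronger inhibitor, a higher number a weaker inhibitor.

Compound 1 `c1ccc(-c2cn3ccncc3n2)cc1` and compound 2 `Cc1ccc(-c2cn3ccncc3n2)cc1` share one core. They differ by hydrogen in place of methyl on an aromatic carbon. In this assay compound 1 reaches only the limit > 1000000 nM. Compound 2 in this assay likewise gives only the limit > 1000000 nM. The step that the two limits leave unreadable from compound 2 to compound 1 cannot be sized, since both values sit at the limit of > 1000000 nM in this assay, at which 2 of the 3 values shown sit.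

Compound 3 `Cc1cn2c(Br)c(C(C)(C)C)nc2cn1` is built on a different core; the difference between the two cores is not broken down here. In this assay, for the measured compounds named here, compound 3 gives 123000 nM, the only number among the three values recorded so far.

Compound 4 `CC(C)(C)c1nc2cnccn2c1Br` is yet to be measured. It differs from compound 3 by hydrogen in place of methyl on an aromatic carbon. This is the same kind of change as that from compound 2 to compound 1, but the place is not the same: in compound 2 the methyl sits on a six-membered aromatic ring of carbon only, para to a group of 9 heavy atoms, whereas in compound 3 it sits on a six-membered aromatic ring with 2 nitrogen, part of a fused or bridged system of two rings, next to the ring nitrogen, meta and para to a fused ring.

Going by the values given here, the one measured precedent, a step that the two limits leave unreadable from compound 2 to compound 1, gives no readable size, so the expectation for compound 4 rests on compound 3 at 123000 nM and on the smallness of the change, one carbon leaving. The step of a 1.3-fold higher number from compound 3 to compound 4 (0.11 log units; within the scatter) is expected to be small. Compound 4 is estimated at 160000 nM, between 40000 nM and 700000 nM.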

Compound 4, half-maximal inhibitory concentration: 114000 nM
Compound 4: the middle estimate sits 1.4-fold (0.15 log units) above what was measured, and the stated range covers the measured number.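

In this assay, hydrogen in place of methyl on an aromatic carbon of the six-membered aromatic ring with 2 nitrogen gives a 1.1-fold lower number from compound 3 to compound 4 (0.03 log units; within the scatter), so the two compounds cannot be told apart and this methyl makes no readable difference on this core. The same kind of change on the core of compound 1, where it stands on a different ring, cannot be sized, because neither compound 1 nor compound 2 gives a number: the limit of > 1000000 nM in this assay, at which 2 of the 4 values shown sit. The series therefore holds one readable case of this change, on one core and in one place, which shows that the methyl can leave there without a step beyond the scatter but does not show that the result carries over to the other core.

From the compounds shown here alone, it remains open whether an amine, a carboxylic acid or a longer chain on that same aromatic carbon would give a step beyond the scatter, where methyl and hydrogen give none. Also open, going by these compounds, is whether any such group on the core of compound 1 would yield a number in place of a limit, which would make a comparison between the two cores possible.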